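Cytotoxicity notes: benzamide replacing ester chain on compound 3

A few compounds are considered here, and "the series" means these few. Any claim that something is new, unique, unknown or untested is made for them only; others in the source may bear on it.

In an ADME assay on HepG2 2.2.15 cells (Homo sapiens) for cytotoxicity (a lower number here means that less compound is tolerated, a higher number that more compound is tolerated), compound 1 `O=C(Nc1ncc(Cc2ccc(F)cc2)s1)c1ccc(Br)cc1` gives > 50000 nM, which is a limit of the assay rather than a number. Compound 2 `O=C(Nc1ncc(Cc2ccc(Br)cc2)s1)c1cccs1` likewise gives > 50000 nM, again a limit. Compound 3 `COC(=O)CCCCNc1ncc(C(Oc2ccc3cc(Br)ccc3c2)c2ccc(Cl)cc2)s1` is reported only as "not toxic" (no number reported) in this assay, with no number, and so stands alongside the limit of > 50000 nM in this assay, at which 2 of the 3 values shown sit, rather than at any measured value. For the measured compounds named here, no step between measured compounds is available. Compound 4 `O=C(Nc1ncc(C(Oc2ccc3cc(Br)ccc3c2)c2ccc(Cl)cc2)s1)c1ccccc1` differs from compound 3 by benzoyl in place of 4-(methoxycarbonyl)butyl on a nitrogen on an aromatic ring. Going by the values given here, with every value so far sitting at a limit or reported without a number, no shift beyond the scatter is expected in this assay in either direction. For compound 4 the half-maximal cytotoxic concentration is estimated at 50000 nM, within 20000 nM to 100000 nM, and most likely it is reported again only as a limit.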

Compound 4, half-maximal cytotoxic concentration: "not toxic" (no number reported)
For compound 4 the study gives words and no number, and the estimate cannot be compared.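

No step can be read between compound 3 and compound 4 in this assay, as both are reported only as "not toxic", without a number. The compounds shown leave open the concentration at which any of them becomes toxic, the only figure being a limit: the limit of > 50000 nM in this assay, at which 2 of the 4 values shown sit.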